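Quinoline carboxamide series: ethoxy for fluoro at compound 3

The source may report more compounds than this note shows. Statements on the series, on what has been measured and on what is new or still open speak of the compounds shown alone.

Compound 2 `Cc1c(C(=O)Nc2c(F)cc(-c3cccc(F)c3)cc2F)nc2ccc(F)cc2c1O` is the lower of the two numbers measured in a functional assay on Hep 3B2 cells (Homo sapiens) for antiproliferative activity, read by MTT assay, with a stated time of 24 h, tested at 0.05 ug/mL (a lower number here means a weaker effect, a higher number a stronger effect of the compound at the concentration tested), where compound 2 gives 1.25%. Among the compounds with values here, its nearest neighbour is compound 1 `CCc1ccc2nc(C(=O)Nc3c(F)cc(-c4cccc(F)c4)cc3F)c(C)c(O)c2c1`, which in this assay gives 5.62%; the only measured step, a number 4.4 percentage points lower from compound 1 to compound 2 (within the scatter), places both compounds at the weak end of the scale with no separation beyond the scatter.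

Compound 3 `CCOc1ccc2nc(C(=O)Nc3c(F)cc(-c4cccc(F)c4)cc3F)c(C)c(O)c2c1` differs from compound 2 by ethoxy in place of fluoro on an aromatic carbon. Within the data shown here, no measured step covers an ethoxy group entering at this place, so the only bearing comes from the ethyl-to-fluoro step from compound 1 to compound 2, which was itself within the scatter. Both measured values sit close to zero inhibition, and nothing in the data points to a move away from that region. For compound 3 no step beyond the scatter is therefore expected in this assay, the expected step being a number 2.8 percentage points higher from compound 2 to compound 3 (within the scatter). The estimate for compound 3 in this assay is 4%, with a range from -6% to 15%.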

Compound 3, a percentage reported as inhibition, at one concentration (the size of the read-out at that concentration, not a potency): -0.04%
Compound 3: the middle estimate sits 4 percentage points above what was measured; measured number inside the range.
By their numbers in this assay, from the lowest: compounds 3, 2 and 1 (each within the scatter of the next).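

Working notes on the substituent at this aromatic carbon, on a six-membered aromatic ring of carbon only: in this assay, ethoxy in place of fluoro gives a number 1.3 percentage points lower from compound 2 to compound 3 (within the scatter), and ethoxy in place of ethyl gives a number 5.7 percentage points lower from compound 1 to compound 3 (within the scatter). The position has now carried three groups on the shared core, and the read-out does not separate them, even though the change from fluoro to ethoxy takes the substituent from 1 heavy atom to 3 and adds 1 hydrogen-bond acceptor. At this single concentration, the series therefore shows no sensitivity to these three groups at this place, and no information is available on what lies behind this flat result.

On these data alone, whether any group at this position can lift the read-out clear of the scatter remains open, and an amine, a carboxylic acid or a longer alkoxy chain would test this on the same core. With all three values close to zero, a single concentration also leaves open whether these compounds would separate at higher concentrations.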